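Ring size change on the aminomethyl arm of compound 2

The compounds below may be only part of what the source reports. "The series", "measured", "known", "first", "only" and "open" are said of these compounds alone.

Measured so far:
compound 1 `Cc1cc(=O)c2c(O)cc(OCc3ccccc3Br)c([C@H]3CCN(C)C[C@H]3O)c2o1`: 3%
compound 2 `Cc1cc(=O)c2c(O)c(CN3CCCC3)c(O)c([C@H]3CCN(C)C[C@H]3O)c2o1`: 38%

In a functional assay on HL-60 cells (Homo sapiens) for inhibition, read by MTT assay, with a stated time of 48 h, tested at 10 uM (on this read-out lower numbers stand for less inhibition of growth and higher numbers for more inhibition of growth at the one concentration tested), compound 1 gives 3% and compound 2 gives 38%. Compound 2 stands highest of the two numbers measured; its nearest neighbour, compound 1, lies lower by a gap that is beyond the scatter. Going by the values given here, the two measured compounds differ in more than one place, so no single-site step between them can be assigned, and the series offers no measured step of the kind now considered.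

Compound 3 `Cc1cc(=O)c2c(O)c(CN3CCCCC3)c(O)c([C@H]3CCN(C)C[C@H]3O)c2o1` is not yet measured. It differs from compound 2 in one place: piperidin-1-yl in place of pyrrolidin-1-yl on a saturated chain carbon bound to an aromatic carbon. The rest of the core of compound 2 is kept unchanged.

Without a measured precedent for this ring size change, the step from compound 2 to compound 3 is expected to be small, no change at the digits printed from compound 2 to compound 3 (within the scatter), with no clear direction and nothing beyond the scatter. Compound 3 is therefore expected to give about 38% in this assay, estimated within a range from 18% to 58%.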

Compound 3, percent growth inhibition at one concentration: 32%
Compound 3: middle estimate off by 6 percentage points, on the high side; the measured number falls inside the stated range.
By their numbers in this assay, from the lowest: compound 1; then compounds 3 and 2 (each within the scatter of the next).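

In this assay, the (pyrrolidin-1-yl)methyl arm now has its first single-site comparison, and the step reads a number 6 percentage points lower from compound 2 to compound 3 (within the scatter), for piperidin-1-yl in place of pyrrolidin-1-yl on a saturated chain carbon bound to an aromatic carbon. At this place, therefore, the five-membered and six-membered non-aromatic rings cannot be told apart at the one concentration tested, and the read-out stays in the same range with compound 3 at 32%. Nothing at hand bears on what underlies this result.

Still open, as far as these compounds go, is whether the same place accepts an arm with a second ring hetero atom, such as morpholin-4-yl or 4-methylpiperazin-1-yl, or an open-chain amine, such as dimethylamino, without a step beyond the scatter. A single concentration also leaves open whether compound 2 and compound 3 would remain indistinguishable across a full concentration series in this assay.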